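The source may report more compounds than this note shows. Statements on the series, on what has been measured and on what is new or still open speak of the compounds shown alone.

Three compounds have so far been examined in a functional assay on HCT-116 cells (Homo sapiens) for inhibition (on this read-out higher numbers stand for weaker inhibition and lower numbers for stronger inhibition), and none has given a number. Compound 1 `FC(F)(F)c1ccc(/C=C\c2ccc3ccccc3c2)cc1` gives > 5000 nM, which is a limit of this assay. Compound 2 `O=S(=O)(c1ccccc1)n1ccc2cc(/C=C\c3ccc4ccccc4c3)ccc21` gives > 5000 nM, also a limit. Compound 3 `C(=C\c1ccc2[nH]ccc2c1)\c1ccc2ccccc2c1` gives > 5000 nM, again a limit rather than a number. Compound 3 therefore has no measured potency of its own, and the record is uniform: the limit of > 5000 nM in this assay, at which 3 of the 3 values shown sit.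

The next compound is compound 4 `Cn1ccc2cc(/C=C\c3ccc4ccccc4c3)ccc21`, which differs from compound 3 by a single change: methyl in place of hydrogen on an aromatic nitrogen. Within the data shown here, the only measured step at this nitrogen is a step that the two limits leave unreadable from compound 2 to compound 3, with hydrogen in place of phenylsulfonyl, and it offers no size to carry over. Neither of the two groups tried there has produced a number, so the data favour no direction for the new methyl. Since compound 3 gives > 5000 nM, a limit, compound 4 is expected to remain close to it. The expected change is a number no higher from compound 3 to compound 4 (the limit leaves the size open), an estimate with no firm direction and no size beyond the scatter. Compound 4 is estimated at 5000 nM, with an expected range from 1500 nM to 15000 nM.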

Compound 4, half-maximal inhibitory concentration: > 5000 nM
Compound 4: a limit, no number; the forecaster's own chance of this, stated with the estimate: 70%; the middle value lies on the limit itself.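

In this assay compound 4 gives > 5000 nM, a limit and not a number, so the steps to it from compound 2 and from compound 3 cannot be read. The compounds shown leave open whether any group on this aromatic nitrogen yields a measurable potency, and the record stays uniform: the limit of > 5000 nM in this assay, at which 4 of the 4 values shown sit.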